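The source may hold more compounds than are shown below. What is called first, only, known or untested is meant among the compounds shown, and "the series" means these compounds.

Compound 1 `COc1cc(-c2nn(-c3ccc(NC(=O)Nc4ccc(Cl)c(C(F)(F)F)c4)cc3)cc2-c2ccncc2)ccc1Cl` was tested in a functional assay on SK-MEL-2 cells (Homo sapiens) for antiproliferative activity, read by sulforhodamine B assay, with a stated time of 48 h (a lower number here means a stronger inhibitor, a higher number a weaker inhibitor), where compound 1 gives 1630 nM. Compound 2 `COc1cc(-c2nn(-c3ccc(NC(=O)Nc4cc(C(F)(F)F)cc(C(F)(F)F)c4)cc3)cc2-c2ccncc2)ccc1Cl` differs from compound 1 in a larger part of the molecule, and the difference between the two cores is not broken down here. In this assay compound 2 gives 1700 nM. Compound 3 `O=C(Nc1ccc(-n2cc(-c3ccncc3)c(-c3ccc(Cl)c(O)c3)n2)cc1)Nc1ccc(Cl)c(C(F)(F)F)c1` is compound 1 with a single change, (hydrogen in place of methyl on an oxygen on an aromatic ring), and in this assay compound 3 gives 1700 nM. That change moved the number by a 1.0-fold higher number from compound 1 to compound 3 (0.02 log units; within the scatter), so on the core of compound 1 the methyl on the oxygen left the result unchanged within the usual scatter. Compound 4 `O=C(Nc1ccc(-n2cc(-c3ccncc3)c(-c3ccc(Cl)c(O)c3)n2)cc1)Nc1cc(C(F)(F)F)cc(C(F)(F)F)c1` is yet to be measured in this assay. It differs from compound 2 by the same change, (hydrogen in place of methyl on an oxygen on an aromatic ring), at the same place. The step expected from compound 2 to compound 4 is no change at the digits printed from compound 2 to compound 4 (within the scatter), because a 1.0-fold higher number from compound 1 to compound 3 (0.02 log units; within the scatter) stayed within the scatter on the other core. Compound 4 is therefore estimated at 1700 nM, with a likely range from 900 nM to 3300 nM.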

Compound 4, half-maximal inhibitory concentration: 1800 nM
Beside the measured number, compound 4's estimate is 1.1-fold (0.02 log units) below it; measured number inside the range.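

On the core of compound 2, replacing methoxy with hydroxy gave a 1.1-fold higher number from compound 2 to compound 4 (0.02 log units; within the scatter) in this assay. Set beside the earlier step, the result on the two cores agrees: the same change on two cores in this assay, a 1.0-fold higher number (0.02 log units; within the scatter) from compound 1 to compound 3 and a 1.1-fold higher number (0.02 log units; within the scatter) from compound 2 to compound 4, 1.0-fold (0.01 log units) apart, within the scatter of two such steps. Within the data shown here, this shows that on these two cores the swap can be carried across with no measurable change in this read-out, but it rests on only one pair of compounds per core, and since neither step goes beyond the usual scatter, it does not show that a change with a real effect would carry across in the same way.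

The compounds shown leave open whether a larger group on this oxygen, such as a longer chain, or an amine in place of the hydroxy would move the number. They also leave open whether methoxy and hydroxy would still match on a core that carries other groups, or in a different test.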